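This account rests on a few compounds, and the source may have more. Where it says the series, first, only, none or still open, it means among the compounds named here.

Values so far in a functional assay on MOLT-4 cells (Homo sapiens) for inhibition, read by sulforhodamine B assay, with a stated time of 48 h; a higher number here means a weaker inhibitor of growth, a lower number a stronger inhibitor of growth:
compound 1 `Cc1ccc(C2=NN(c3ccc(S(C)(=O)=O)cc3)C(=O)CC2)cc1` gives 860 nM
compound 2 `Cc1cc(O)ccc1C1=NN(c2ccc(S(C)(=O)=O)cc2)C(=O)CC1` gives 14300 nM
compound 3 `CCc1ccc(C2=NN(c3ccc(S(C)(=O)=O)cc3)C(=O)CC2)cc1` is not yet measured

Compound 2 has the higher of the two numbers, at 14300 nM and is the weaker growth inhibitor of the pair. For the measured compounds named here, the only measured step is large: a 17-fold higher number from compound 1 to compound 2 (1.22 log units; beyond the scatter) on moving to the 4-hydroxy-2-methylphenyl group.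

The next change is 4-ethylphenyl in place of 4-hydroxy-2-methylphenyl on a carbon with a double bond to nitrogen and it sits on a carbon with a double bond to nitrogen. The 4-ethylphenyl group of compound 3 resembles the 4-methylphenyl group of compound 1 more closely than the group of compound 2, so the measured step should apply largely in reverse. Going by the values given here, no measured step covers the change from 4-methylphenyl to 4-ethylphenyl, which leaves the main uncertainty and widens the range. Among the compounds with values here, this expectation rests on compound 1 at 860 nM and on a 17-fold higher number from compound 1 to compound 2 (1.22 log units; beyond the scatter) as its only measured step.

The expected change in this assay is large and towards a lower number, estimated as a 16-fold lower number from compound 2 to compound 3 (1.20 log units; beyond the scatter) (beyond the scatter if it holds). For compound 3 the estimated value is 900 nM (expected range 300 nM to 2800 nM).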

Compound 3, concentration for 50% growth inhibition: 3520 nM
Compound 3: middle estimate off by 3.9-fold (0.59 log units), on the low side; the measured number lies above the stated range.
By their numbers in this assay, from the lowest: compound 1; then compound 3; then compound 2.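

In this assay, methyl in place of hydrogen on the saturated chain carbon bound to an aromatic carbon, which turns 4-methylphenyl into 4-ethylphenyl, gives a 4.1-fold higher number from compound 1 to compound 3 (0.61 log units; beyond the scatter) and so shows that this group tolerates even that small addition poorly, something compound 1 and compound 2 alone could not reveal. Putting 4-ethylphenyl in place of 4-hydroxy-2-methylphenyl gives a 4.1-fold lower number from compound 2 to compound 3 (0.61 log units; beyond the scatter) and recovers only part of the earlier 17-fold higher number from compound 1 to compound 2 (1.22 log units; beyond the scatter) on this carbon with a double bond to nitrogen, so compound 3 falls between the other two and compound 1 remains the strongest growth inhibitor of the three. Nothing available explains either step.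

The compounds shown leave open whether the trend continues with a longer chain such as propyl, or with a branched isopropyl group, in place of ethyl. In 4-hydroxy-2-methylphenyl the hydroxy and the extra methyl enter together, so their separate shares of the loss stay unresolved, and an amine or a carboxylic acid on this aromatic ring remains an untested kind of substituent in this set.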